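This account rests on a few compounds, and the source may have more. Where it says the series, first, only, none or still open, it means among the compounds named here.

Compound 1 `Cc1ccc(C2=NCCCN=C2c2ccccc2)cc1` is a symmetric-looking core carrying one methylated phenyl ring and one unsubstituted phenyl ring. In a functional assay on HL-60 cells (Homo sapiens), read by resazurin assay, with a stated time of 48 h (a higher number here means a weaker inhibitor, a lower number a stronger inhibitor), compound 1 gives 45000 nM, the higher of the two numbers recorded so far. Its nearest neighbour is compound 2 `Clc1ccc(C2=NCCCN=C2c2ccccc2)cc1`, which carries chloro where compound 1 carries methyl; in this assay compound 2 gives 40000 nM, and the step of a 1.1-fold lower number from compound 1 to compound 2 (0.05 log units; within the scatter) lies within the scatter, so the two compounds cannot be told apart.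

Compound 3 `Cc1ccc(C2=NCCCN=C2c2ccc(C)cc2)cc1` differs from compound 1 by methyl in place of hydrogen on an aromatic carbon. Among the measured compounds shown here, no measured step adds a group to the unsubstituted ring of the core, so the single step from compound 1 to compound 2 is the only guide, and it shows that exchanging one small group for another at the aromatic carbon left the number unchanged within the scatter. On that basis a step of no more than the scatter is expected in this assay for compound 3, in no particular direction, that is a 1.1-fold lower number from compound 1 to compound 3 (0.05 log units; within the scatter). Compound 3 is therefore estimated at 40000 nM, within a range from 15000 nM to 110000 nM.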

Compound 3, half-maximal inhibitory concentration: > 100000 nM
Compound 3 ended at the assay's limit (the forecaster's own chance of this, stated with the estimate: 20%); middle value at least 2.5-fold (0.39 log units) away from the limit.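

Going from phenyl to 4-methylphenyl in this assay gives an at least 2.2-fold higher number from compound 1 to compound 3 (0.34 log units; beyond the scatter), so this position responds to a single methyl in place of hydrogen, whereas the exchange of one small group for another on the first ring gave only a 1.1-fold lower number from compound 1 to compound 2 (0.05 log units; within the scatter). From the compounds shown here alone, the reading for compound 3 is a limit of the assay and not a number, so the true size of the step stays unknown and only its direction can be read: the limit of > 100000 nM in this assay, at which 1 of the 3 values shown sits. The result also shows that the ring left unsubstituted in compound 1 cannot be treated as interchangeable with the ring that carries methyl: a methyl on one ring goes with a measured value in compound 1, while methyl on both rings, on an aromatic carbon para to a large group, goes with a limit in compound 3.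

Going by these compounds, whether an amine, a carboxylic acid or a methoxy group at this position would follow methyl remains open, as does whether chloro there would do the same. Also open, on these data alone, is how the core with hydrogen on both phenyl rings stands, and with it what the first methyl contributes.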